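The source may report more compounds than this note shows. Statements on the series, on what has been measured and on what is new or still open speak of the compounds shown alone.

Measured compounds:
Compound 1, `CC(C)=CCC1Cc2c(OCc3ccccc3)cc(=O)n(CCCO)c2CC1(C)C`, gives -0.3% in a functional assay on PANC-1 cells (Homo sapiens) for inhibition, read by MTT assay, with a stated time of 24 h, tested at 10 uM; on this read-out lower numbers stand for less inhibition and higher numbers for more inhibition at the one concentration tested (going by the name of the read-out).
Compound 2, `CC(C)=CCC1Cc2c(OCCCNC(=O)c3ccc([N+](=O)[O-])cc3)cc(=O)n(CCCO)c2CC1(C)C`, gives 49.9%.
Compound 3, `COc1ccc(OCCCOc2cc(=O)n(CCCO)c3c2CC(CC=C(C)C)C(C)(C)C3)cc1`, gives 47.7%.

Compound 3 stands second highest of the three numbers. Its nearest neighbour is compound 2, separated by a step that reads a number 2.2 percentage points lower from compound 2 to compound 3 (within the scatter), so the two cannot be ordered. Among the compounds with values here, the only step beyond the scatter is a number 48 percentage points higher from compound 1 to compound 3 (beyond the scatter), where a longer ether chain takes the place of the benzyl group.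

Compound 4, `CC(C)=CCC1Cc2c(OCCCOc3ccc([N+](=O)[O-])cc3)cc(=O)n(CCCO)c2CC1(C)C`, has not yet been tested. It differs from compound 3 in one place: nitro in place of methoxy on an aromatic carbon. The step that bears most directly on this is the exchange of the whole chain end, which compound 2 and compound 3 show as a number 2.2 percentage points lower from compound 2 to compound 3 (within the scatter): a nitro-bearing chain end and a methoxy-bearing chain end gave numbers within the scatter of each other. Within the data shown here, no measured step separates a nitro from a methoxy on the same ring, so the expectation rests on that one comparison. Compound 4 is therefore expected to sit close to compound 3, with a step of about a number 0.3 percentage points higher from compound 3 to compound 4 (within the scatter), not beyond the scatter. The estimate for compound 4 is 48%, in a range from 35% to 61%.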

Compound 4, a percentage reported as inhibition, at one concentration (the size of the read-out at that concentration, not a potency): 47.5%
Estimate against measurement, compound 4: 0.5 percentage points above, and the stated range covers the measured number.
By their numbers in this assay, from the lowest: compound 1; then compounds 4, 3 and 2 (each within the scatter of the next).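

In this assay, the exchange of nitro for methoxy on the aromatic carbon para to a large group is now seen directly, and a number 0.2 percentage points lower from compound 3 to compound 4 (within the scatter), so the two groups cannot be ordered at this position. The whole chain end cannot be ordered either, since a number 2.4 percentage points lower from compound 2 to compound 4 (within the scatter), while a number 47.8 percentage points higher from compound 1 to compound 4 (beyond the scatter) shows that the large step first seen with the methoxy-bearing chain end also appears with a nitro-bearing one. Nothing at hand gives a cause for any of these steps.

The compounds shown leave open whether an amine or a carboxylic acid on this aromatic carbon would give a number close to those of compound 3 and compound 4. They also leave open how a longer chain between the two oxygens would read in this assay.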